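The source may report more compounds than this note shows. Statements on the series, on what has been measured and on what is new or still open speak of the compounds shown alone.

Compounds measured so far:
Compound 1 `C=C1C(=O)O[C@H](C2=C(C)C(O)CC2=O)[C@@H]1CCC(C)=O` gives 2%.
Compound 2 `C=C1C(=O)O[C@H](C2=C(C)[C@@H](OC)CC2=O)[C@@H]1CCC(C)=O` gives 7%.

In a functional assay on HaCaT cells (Homo sapiens) for cytotoxicity, read by ELISA and LDH release, with a stated time of 6 h, tested at 15 ug/mL (on this read-out higher numbers stand for a weaker effect at the one concentration tested and lower numbers for a stronger effect), compound 1 gives 2%, and compound 2 gives 7%. The two numbers lie within the usual scatter of each other, so compound 2 does not stand apart from compound 1 on this read-out. Compound 3 `C=C1C(=O)O[C@H](C2=C(C)[C@@H](O)CC2=O)[C@@H]1CCC(C)=O` differs from compound 2 in one place: hydrogen in place of methyl on an oxygen on a saturated carbon. Among the compounds with values here, no measured pair shows this change, so its size is not known from the data. The expected step of a number 2 percentage points lower from compound 2 to compound 3 (within the scatter) is no larger than the scatter, in no clear direction. In this assay compound 3 is therefore estimated at 5%, between 0% and 18%.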

Compound 3, a percentage reported as activity, at one concentration (the size of the read-out at that concentration, not a potency): 0%
The estimate for compound 3 lay 5 percentage points above the measured number; measured number inside the range.
By their numbers in this assay, from the lowest: compounds 3, 1 and 2 (each within the scatter of the next).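

In this assay, methoxy to hydroxy, hydrogen in place of methyl on an oxygen on a saturated carbon, gives a number 7 percentage points lower from compound 2 to compound 3 (within the scatter), so this change does not separate the two compounds. The stereocentre at the saturated ring carbon, drawn as S in compound 3, gives a number 2 percentage points lower from compound 1 to compound 3 (within the scatter), and this pair differs only in how that stereocentre is drawn: the fact that one of compounds 1 and 3 is drawn with a defined configuration and the other without, at the place where they differ

As far as these compounds go, whether an amine or a longer chain on this carbon would give a step beyond the scatter stays open. So does the reading for the R configuration at this stereocentre.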